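The source may report more compounds than this note shows. Statements on the series, on what has been measured and on what is new or still open speak of the compounds shown alone.

Of the compounds shown here, three built on one shared core have been read in an ADME assay on MDBK cells (Bos taurus) for cytotoxicity, read by MTT assay, with a stated time of 96 h; on this read-out higher numbers stand for lower toxicity in this test and lower numbers for higher toxicity in this test. Compound 1 `C/C(=N\O)c1ccc2[nH]c(-c3ccc(Cl)cc3)nc2c1` gives 37000 nM. Compound 2 `C/C(=N\NC(N)=O)c1ccc2[nH]c(-c3ccc(Cl)cc3)nc2c1` reaches only a limit of the assay, > 100000 nM. Compound 3 `C/C(=N\NC(N)=S)c1ccc2[nH]c(-c3ccccc3)nc2c1` gives 32000 nM, a value within the scatter of that of compound 1. Compound 4 `C/C(=N\NC(N)=S)c1ccc2[nH]c(-c3ccc(Cl)cc3)nc2c1` is still unmeasured. It differs from compound 3 by chloro in place of hydrogen on an aromatic carbon, para to a large group: chloro in place of hydrogen on an aromatic carbon. For the measured compounds named here, the only measured step, an at least 2.7-fold higher number from compound 1 to compound 2 (0.43 log units; beyond the scatter), is ureido in place of hydroxy on a double-bonded nitrogen, a different change in a different place, so it does not bear on this one. Going by the values given here, no measured pair isolates the chloro change, and the expectation therefore stays anchored on compound 3 at 32000 nM. The estimated 1.1-fold lower number from compound 3 to compound 4 (0.06 log units; within the scatter) is expected to stay within the scatter, with no clear direction. For compound 4 the expected value is 28000 nM, with an estimated range of 9000 nM to 85000 nM.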

Compound 4, half-maximal cytotoxic concentration: > 100000 nM
Compound 4: a limit, no number (the forecaster's own chance of this, stated with the estimate: 10%); middle value at least 3.5-fold (0.55 log units) away from the limit.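

In this assay compound 4 gives a limit and not a number, > 100000 nM. Chloro in place of hydrogen on an aromatic carbon, para to a large group, is now read for the first time and gives an at least 3.1-fold higher number from compound 3 to compound 4 (0.49 log units; beyond the scatter), so phenyl to 4-chlorophenyl is not a silent change in this series, while with 4-chlorophenyl kept, the change on the double-bonded nitrogen gives an at least 2.7-fold higher number from compound 1 to compound 4 (0.43 log units; beyond the scatter). The step between compound 2 and compound 4 cannot be read, as both stand at the same limit: the limit of > 100000 nM in this assay, at which 2 of the 4 values shown sit.

From the compounds shown here alone, the true size of the readable steps stays open, since each ends at a limit. Also open, going by these compounds, is what a methoxy group or a bromine atom at this place would give, and whether chloro acts alike with hydroxy or ureido on the double-bonded nitrogen.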